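Swapping a Sulfur Link for a Benzylamine

The compounds below may be only part of what the source reports. "The series", "measured", "known", "first", "only" and "open" are said of these compounds alone.

Measured compounds:
compound 1 `Nc1cc(N)c2nc(-c3ccccc3)c(Sc3ccc(F)cc3)nc2c1`
compound 2 `CCOC(=O)[C@H](CCC(=O)O)NC(=O)c1ccc(CNc2nc3cc(N)cc(N)c3nc2-c2ccccc2)cc1`

Both were tested in a functional assay on M14 cells (Homo sapiens) for inhibition, read by sulforhodamine B assay, with a stated time of 48 h; on this read-out lower numbers stand for stronger inhibition of growth and higher numbers for weaker inhibition of growth. Within the data shown here, compound 1 gives 30900 nM in this assay, and this is the only plain number in the set. Compound 2 is reported in this assay as < 100000 nM, which is a limit of the assay and not a number; it stands at the limit of < 100000 nM in this assay, at which 1 of the 2 values shown sits. With no second number, compound 1 cannot be ranked against anything, so it simply marks the one point of reference.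

Compound 3 `Nc1cc(N)c2nc(-c3ccccc3)c(NCc3ccc(F)cc3)nc2c1` has not been measured. It differs from compound 1 in one place: (4-fluorobenzyl)amino in place of (4-fluorophenyl)sulfanyl on an aromatic carbon. Among the measured compounds shown here, no pair of measured compounds shares this change, so the size of the step is open. A modest step in either direction, not clearly beyond the usual scatter, is expected, and compound 3 is estimated at 40000 nM, within 12000 nM to 100000 nM, which means an expected step of a 1.3-fold higher number from compound 1 to compound 3 (0.11 log units; within the scatter).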

Compound 3, concentration for total growth inhibition: 56200 nM
Estimate against measurement, compound 3: 1.4-fold (0.15 log units) below; the measured number falls inside the stated range.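

In this assay, the exchange of the (4-fluorophenyl)sulfanyl group for (4-fluorobenzyl)amino gives a 1.8-fold higher number from compound 1 to compound 3 (0.26 log units; within the scatter). This step lies within the scatter, so on this read-out the two compounds cannot be told apart, even though the entering group is longer by one heavy atom, has nitrogen where the leaving group has sulfur, and carries a hydrogen-bond donor that the leaving group lacks. Nothing among the data shown explains this outcome.

One pair in one assay cannot say whether this position accepts other links in general. A phenoxy group with an oxygen link, a plain amine with no benzyl group, or a benzylamine with a methoxy group in place of the fluorine could each behave differently at this aromatic carbon.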